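The source may report more compounds than this note shows. Statements on the series, on what has been measured and on what is new or still open speak of the compounds shown alone.

Compound 1, `CCCCCCNCC(=O)Nc1ccc(/C(N)=N/O)cc1`: 658000 nM
Compound 2, `CCCCNCC(=O)Nc1ccc(/C(N)=N/O)cc1`: 395000 nM
Compound 3, `CCCCNCCC(=O)Nc1ccc(/C(N)=N/O)cc1`: 881000 nM

These values come from a functional assay on A549 cells (Homo sapiens) for antiproliferative activity, read by WST assay, with a stated time of 72 h; a lower number here means that less compound is needed, a higher number that more compound is needed for the effect. All three numbers are large, so a great deal of each compound is needed to slow the growth of the cells. The step of a 1.7-fold higher number from compound 2 to compound 1 (0.22 log units; within the scatter) arises from the change (ethyl in place of hydrogen on a saturated chain carbon, four bonds along the chain from an amine nitrogen), a lengthening of the chain on the amine side. The step of a 2.2-fold higher number from compound 2 to compound 3 (0.35 log units; beyond the scatter) arises from the change ((butylamino)methyl in place of butylamino on a saturated chain carbon bound to a carbonyl carbon), which lengthens the chain between the amine nitrogen and the carbonyl instead. Compound 1 and compound 3 are linked by the step of a 1.3-fold higher number from compound 1 to compound 3 (0.13 log units; within the scatter).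

Compound 4, `CCCCCCNCCC(=O)Nc1ccc(/C(N)=N/O)cc1`, has not yet been measured. It differs from compound 3 by ethyl in place of hydrogen on a saturated chain carbon, four bonds along the chain from an amine nitrogen, the same change that separates compound 2 from compound 1, made here on the core of compound 3; the two cores differ by (butylamino)methyl in place of butylamino on a saturated chain carbon bound to a carbonyl carbon, and the place of the change is the same in both cases. Because the earlier step of a 1.7-fold higher number from compound 2 to compound 1 (0.22 log units; within the scatter) stayed within the scatter, a similarly small step is expected here, namely a 1.6-fold higher number from compound 3 to compound 4 (0.20 log units; within the scatter). Compound 4 is therefore estimated to give 1400000 nM, with a likely range from 600000 nM to 3500000 nM.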

Compound 4, half-maximal effective concentration: > 1000000 nM
Compound 4: a limit, no number; the forecaster's own chance of this, stated with the estimate: 25%; the middle value does not contradict the limit.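

In this assay compound 4 gives > 1000000 nM, which is a limit of the assay and not a number. From the compounds shown here alone, the step therefore reads only as a floor, an at least 1.1-fold higher number from compound 3 to compound 4 (0.05 log units; that floor lies within the scatter), so the true size of the change on this core is unknown, and the floor itself does not go beyond the usual scatter. This result does not contradict the idea that adding ethyl in place of hydrogen has a similar effect on both cores, but it does not show that the effect carries over unchanged, as the comparison remains unresolved: the same change on two cores in this assay, a 1.7-fold higher number (0.22 log units; within the scatter) from compound 2 to compound 1 and an at least 1.1-fold higher number (0.05 log units; that floor lies within the scatter) from compound 3 to compound 4; the limit leaves it open whether they differ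

The compounds shown leave open how a longer chain, such as octyl, in place of the hexyl chain would read in this assay, and whether a ring on the chain in its place would give a clearly lower number. They also leave open whether a carboxylic acid in place of the amide would change these high values.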